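This account rests on a few compounds, and the source may have more. Where it says the series, first, only, none or still open, it means among the compounds named here.

Compound 1 `Cc1cc(OCCCCOc2ccc(C(=O)CC3CCCC3)c(O)c2C)ccc1C(=O)O` gives > 10000 nM in an assay on HEK293 cells for positive allosteric modulation of metabotropic glutamate receptor 3 (Rattus norvegicus), read by thallium flux, with a stated time of 2.5 min (on this read-out lower numbers stand for an effect already at smaller amounts and higher numbers for an effect only at larger amounts of compound), a limit of the assay.
Compound 2 `COc1ccc(C(=O)O)cc1OCCCCOc1ccc(C(=O)CC2CCCC2)c(O)c1C` gives 1020 nM in this assay.
Compound 3 `Cc1cc(C(=O)O)ccc1OCCCCOc1ccc(C(=O)CC2CCCC2)c(O)c1C` gives > 10000 nM in this assay, again only a limit.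

Compound 3 thus stands at the limit where two of the three values sit (the limit of > 10000 nM in this assay, at which 2 of the 3 values shown sit), so only an upper bound is known for it. Compound 4 `Cc1c(OCCCCOc2cccc(C(=O)O)c2)ccc(C(=O)CC2CCCC2)c1O` changes the acid-bearing ring: 3-carboxyphenyl in place of 4-carboxy-2-methylphenyl on an oxygen on a saturated carbon. Going by the values given here, two measured steps bear on such changes of this ring. an at least 9.8-fold higher number from compound 2 to compound 3 (0.99 log units; beyond the scatter) and an at least 9.8-fold lower number from compound 1 to compound 2 (0.99 log units; beyond the scatter) show that swapping this ring can move the number at least modestly. The step from compound 1 to compound 3 cannot be read, since both are limits. Compound 4 carries neither the methyl of compound 3 nor the methoxy of compound 2. A number below the limit of compound 3 is expected, an at least 3.3-fold lower number from compound 3 to compound 4 (0.52 log units; beyond the scatter), though a limit remains possible. Compound 4 is estimated at 3000 nM, between 800 nM and 10000 nM.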

Compound 4, half-maximal effective concentration: 3400 nM
Compound 4: the middle estimate sits 1.1-fold (0.05 log units) below what was measured, within the range that was stated.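

Putting 3-carboxyphenyl in place of either methyl-bearing ring gives a readable number, with an at least 2.9-fold lower number from compound 3 to compound 4 (0.46 log units; beyond the scatter) and an at least 2.9-fold lower number from compound 1 to compound 4 (0.46 log units; beyond the scatter). The methoxy of compound 2 now appears as a single change, since hydrogen in its place gives a 3.3-fold higher number from compound 2 to compound 4 (0.52 log units; beyond the scatter), so the methoxy compound has the lower number of this pair. The two steps that start from a limit give only a minimum size: the limit of > 10000 nM in this assay, at which 2 of the 4 values shown sit.

Going by these compounds, whether ethoxy or fluorine in place of that methoxy would lower the number further remains open. So does the effect of an amide in place of the carboxylic acid.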